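A few compounds are considered here, and "the series" means these few. Any claim that something is new, unique, unknown or untested is made for them only; others in the source may bear on it.

Three compounds built on a shared core were measured in a functional assay on PC-6 cells (Homo sapiens) for antiproliferative activity; on this read-out higher numbers stand for weaker inhibition and lower numbers for stronger inhibition. Compound 1 `Cc1ccc(/C=N\Nc2ncnc3sc(C(C)(C)C)cc23)nc1` gives 0.009 ug/mL. Compound 2 `Cc1cccc(/C=N\Nc2ncnc3sc(C(C)(C)C)cc23)n1` gives 0.258 ug/mL, and a 29-fold higher number from compound 1 to compound 2 (1.46 log units; beyond the scatter). Compound 3 `CC(C)(C)c1cc2c(N/N=C\c3cccc(CN)n3)ncnc2s1` gives 0.036 ug/mL; a 4.0-fold higher number from compound 1 to compound 3 (0.60 log units; beyond the scatter), while a 7.2-fold lower number from compound 2 to compound 3 (0.86 log units; beyond the scatter). Compound 3 therefore stands second of the three numbers, between compound 1 and compound 2.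

Compound 4 `CN(C)Cc1cccc(/C=N\Nc2ncnc3sc(C(C)(C)C)cc23)n1` differs from compound 3 by dimethylamino in place of amino on a saturated chain carbon bound to an aromatic carbon. Among the compounds with values here, the only measured step at this position is the one where the amino group arrived, a 7.2-fold lower number from compound 2 to compound 3 (0.86 log units; beyond the scatter), a modest gain. Within the data shown here, no measured step shows what follows when the hydrogens of that amino group are exchanged for methyl groups, so the direction of the present step is uncertain. Because the gain in a 7.2-fold lower number from compound 2 to compound 3 (0.86 log units; beyond the scatter) came with the amino group and compound 4 keeps a nitrogen on that carbon, the number is expected to stay near that of compound 3, with at most a small move toward a higher number. Compound 4 is therefore expected to show a 1.4-fold higher number from compound 3 to compound 4 (0.14 log units; within the scatter). Compound 4 is estimated to give 0.05 ug/mL, with a range from 0.015 ug/mL to 0.2 ug/mL.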

Compound 4, half-maximal inhibitory concentration: 0.381 ug/mL
For compound 4 the middle estimate is 7.6-fold (0.88 log units) below the measured one; the measured number lies above the stated range.
By their numbers in this assay, from the lowest: compound 1; then compound 3; then compounds 2 and 4 (each within the scatter of the next).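

In this assay, the gain seen with the amino group on this saturated chain carbon does not carry over to dimethylamino, and the exchange is a large step in the weaker direction (an 11-fold higher number from compound 3 to compound 4 (1.02 log units; beyond the scatter)). The number for the dimethylamino compound also stays within the scatter of the one with hydrogen at that place (a 1.5-fold higher number from compound 2 to compound 4 (0.17 log units; within the scatter)), so among these compounds the gain belongs to the amino group and not to any nitrogen on that carbon. The information given here offers no explanation for this difference.

The compounds shown leave open whether methylamino, which lies in kind between amino and dimethylamino, would behave more like compound 3 or compound 4. They also leave open how a ring amine such as morpholine, or a longer chain carrying the amino group, would fare at this place.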